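The compounds below may be only part of what the source reports. "The series", "measured", "known", "first", "only" and "open" are said of these compounds alone.

Compound 1 `COc1cc2c(Oc3ccc(NC(=O)c4nn(-c5ccccc5C)cc(C)c4=O)c(F)c3)ccnc2cc1OCCCCCCC(=O)NO`: in a functional assay on MCF7 cells (Homo sapiens) for inhibition, read by MTT assay, with a stated time of 72 h (a lower number here means a stronger inhibitor, a higher number a weaker inhibitor), compound 1 gives 2690 nM.
Compound 2 `COc1cc2c(Oc3ccc(NC(=O)c4nn(-c5ccccc5C)cc(C)c4=O)cc3)ccnc2cc1OCCCCCC(=O)NO`: in this assay compound 2 gives 1830 nM.
Compound 3 `COc1cc2c(Oc3ccc(NC(=O)c4nn(-c5ccccc5C)ccc4=O)cc3)ccnc2cc1OCCCCCC(=O)NO`: in this assay compound 3 gives 4360 nM.

Compounds 2 and 3 differ in one place only: hydrogen in place of methyl on an aromatic carbon. That single change made a 2.4-fold higher number from compound 2 to compound 3 (0.38 log units; beyond the scatter), so the weaker inhibitor is compound 3. Compound 1 is built on a closely related core, but the difference between the two cores is not broken down here; the values of compound 1 and compound 2 lie within the usual scatter of each other, as do those of compound 1 and compound 3.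

Compound 4 `COc1cc2c(Oc3ccc(NC(=O)c4nn(-c5ccccc5C)ccc4=O)c(F)c3)ccnc2cc1OCCCCCCC(=O)NO` has not been measured yet. It differs from compound 1 in exactly the way compound 3 differs from compound 2: hydrogen in place of methyl on an aromatic carbon. The surroundings of the changed position are the same in both pairs, so this is the same change made on a second core. A step of similar size is expected, because compound 1 gives 2690 nM and the earlier step was a 2.4-fold higher number from compound 2 to compound 3 (0.38 log units; beyond the scatter). In this assay compound 4 is therefore expected to give about 6400 nM, most likely between 3000 nM and 13500 nM, which would be a step of a 2.4-fold higher number from compound 1 to compound 4 (0.38 log units; beyond the scatter).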

Compound 4, half-maximal inhibitory concentration: 3650 nM
Compound 4: the middle estimate sits 1.8-fold (0.24 log units) above what was measured; low and high end bracket the measured number.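

On the core of compound 1, hydrogen in place of methyl gives a 1.4-fold higher number from compound 1 to compound 4 (0.13 log units; within the scatter), so in this assay this step alone cannot be told apart from the usual scatter of repeated measurements. Set beside the earlier step, it does not differ by more than that scatter allows, so the two pairs are compatible with the change carrying over from one core to the other: the same change on two cores in this assay, a 2.4-fold higher number (0.38 log units; beyond the scatter) from compound 2 to compound 3 and a 1.4-fold higher number (0.13 log units; within the scatter) from compound 1 to compound 4, 1.8-fold (0.24 log units) apart, within the scatter of two such steps. Among these compounds, this does not show that the step has one fixed size, as only two pairs stand behind it, one step lying beyond the scatter and the other within it, and it gives no reason for either result.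

The compounds shown leave open how a different group in place of that methyl, such as an ethyl group, a chlorine atom or an amine, would behave on either core. They also do not separate the individual differences between the core of compound 1 and the core of compound 2.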